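The source may hold more compounds than are shown below. What is called first, only, known or untested is meant among the compounds shown, and "the series" means these compounds.

Measured so far:
compound 1, `CC1=CCC[C@@H]2[C@@](C)(C[C@H](O)C3=CCOC3=O)[C@H](C)CC[C@@]12C` — 3.3 ug/mL
compound 2, `CC1=CCC[C@@H]2[C@@](C)(C[C@H](O)C3=CC(=O)O[C@H]3O)[C@H](C)CC[C@@]12C` — 4.1 ug/mL

In an ADME assay on LNCaP cells (Homo sapiens) for cytotoxicity (a lower number here means that less compound is needed, a higher number that more compound is needed for the effect), compound 1 gives 3.3 ug/mL, and compound 2 gives 4.1 ug/mL. Among the compounds with values here, compound 2 thus carries the highest of the two numbers recorded, but its nearest neighbour is compound 1, and the only measured step, a 1.2-fold higher number from compound 1 to compound 2 (0.09 log units; within the scatter), lies within the scatter, so the two cannot be told apart.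

Compound 3, `CC1=CCC[C@@H]2[C@@](C)(CCC3=CC(=O)O[C@H]3O)[C@H](C)CC[C@@]12C`, has not been measured. It differs from compound 2 in one place: hydrogen in place of hydroxy on a saturated chain carbon bound to a double-bonded ring carbon and a saturated chain carbon.

Within the data shown here, no measured step touches this position. The step from compound 1 to compound 2 concerns a different part of the molecule, and it was itself within the scatter; it offers no guidance on the direction or size of the present change. With nothing pointing either way, the expected step of a 1.1-fold higher number from compound 2 to compound 3 (0.04 log units; within the scatter) is none beyond the scatter. For compound 3 the estimate in this assay is therefore 4.5 ug/mL, with a range from 2 ug/mL to 10 ug/mL to reflect the uncertainty of an unprecedented change.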

Compound 3, concentration for half-maximal effect: 3.3 ug/mL
Compound 3: the middle estimate sits 1.4-fold (0.13 log units) above what was measured; the measured number falls inside the stated range.
By their numbers in this assay, from the lowest: compounds 1, 3 and 2 (each within the scatter of the next).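

In this assay, the change of hydroxy to hydrogen on a saturated chain carbon bound to a double-bonded ring carbon and a saturated chain carbon gives a 1.2-fold lower number from compound 2 to compound 3 (0.09 log units; within the scatter), so compound 2 and compound 3 cannot be told apart. Within the data shown here, this is the first measured step at this position, and it shows that in this cell read-out the number does not depend measurably on the hydroxy there, at least with the ring group shared by these two compounds. Nothing available explains this result or links it to any property of the hydroxy.

The compounds shown leave open whether an amine, a methoxy group or a carboxylic acid on the same carbon would also stay within the scatter of compound 2, or whether only the hydroxy and hydrogen behave alike. Among these compounds, they also leave open whether the same swap of hydroxy for hydrogen would give so small a step when the ring group of compound 1 stands in place of the one in compound 2.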